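Swapping a Urea Partner for an Amide: Predicting Compound 4

The source may hold more compounds than are shown below. What is called first, only, known or untested is meant among the compounds shown, and "the series" means these compounds.

Of the compounds shown here, three sharing one core have been tested in a functional assay on DU-145 cells (Homo sapiens) for inhibition, read by sulforhodamine B assay, with a stated time of 48 h; on this read-out higher numbers stand for weaker inhibition of growth and lower numbers for stronger inhibition of growth. Compound 1 `COc1cc(-c2nn(-c3cccc(NC(=O)c4cccc(C(F)(F)F)c4)c3)cc2-c2ccncc2)ccc1Cl` carries a 3-(trifluoromethyl)phenyl group on a carbonyl carbon, and in this assay compound 1 gives 32100 nM. Compound 2 `COc1cc(-c2nn(-c3cccc(NC(=O)Nc4ccc(Cl)c(Cl)c4)c3)cc2-c2ccncc2)ccc1Cl` puts a (3,4-dichlorophenyl)amino group on that carbonyl, and compound 2 gives 34200 nM, a step of a 1.1-fold higher number from compound 1 to compound 2 (0.03 log units; within the scatter). Compound 3 `COc1cc(-c2nn(-c3cccc(NC(=O)Nc4cccc(C(F)(F)F)c4)c3)cc2-c2ccncc2)ccc1Cl` has a (3-(trifluoromethyl)phenyl)amino group on the carbonyl. For compound 3 this assay reports only a limit, > 50000 nM, so compound 3 has no exact number. Its steps from the other two, an at least 1.5-fold higher number from compound 1 to compound 3 (0.19 log units; that floor lies within the scatter) and an at least 1.4-fold higher number from compound 2 to compound 3 (0.16 log units; that floor lies within the scatter), have floors within the scatter, so no ordering can be claimed.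

Compound 4 `COc1cc(-c2nn(-c3cccc(NC(=O)c4ccc(Cl)c(C(F)(F)F)c4)c3)cc2-c2ccncc2)ccc1Cl` differs from compound 3 by 4-chloro-3-(trifluoromethyl)phenyl in place of (3-(trifluoromethyl)phenyl)amino on a carbonyl carbon. This returns to an amide-type arrangement like that of compound 1 and compound 2, whose difference a 1.1-fold higher number from compound 1 to compound 2 (0.03 log units; within the scatter) barely moved the number. In this assay the expected step is therefore small, an at least 1.6-fold lower number from compound 3 to compound 4 (0.22 log units; that floor lies within the scatter), with a downward lean toward the numbers of compound 1 and compound 2. The estimate for compound 4 is 30000 nM, expected to lie between 12000 nM and 70000 nM.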

Compound 4, concentration for total growth inhibition: > 32500 nM
Compound 4 ended at the assay's limit; the forecaster's own chance of this, stated with the estimate: 35%; at least 1.0-fold (0.03 log units) between middle value and limit.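

In this assay, chloro in place of hydrogen on an aromatic carbon gives an at least 1.0-fold higher number from compound 1 to compound 4 (0.00 log units; that floor lies within the scatter), so adding this chlorine to compound 1 brings no sign of stronger inhibition of growth, though any loss cannot be sized. Compound 4 has only a limit and no exact number: the limit of > 32500 nM in this assay, at which 1 of the 4 values shown sits. The steps joining compound 4 to compound 2 and to compound 3 cannot be read, so replacing either (arylamino) group on the carbonyl carbon with 4-chloro-3-(trifluoromethyl)phenyl has no measurable size here.

Going by these compounds, how far compound 4 lies beyond its limit remains open. Also open, on these data alone, is whether a phenyl ring carrying an amine or a carboxylic acid, in place of the chloro and trifluoromethyl groups, would give an exact number and clearly stronger inhibition.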